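Replacing tert-butyl with methoxy on a weak inhibitor

This account rests on a few compounds, and the source may have more. Where it says the series, first, only, none or still open, it means among the compounds named here.

In a functional assay on HCT-116 cells (Homo sapiens) for antiproliferative activity, read by MTT assay, with a stated time of 72 h (a higher number here means a weaker inhibitor, a lower number a stronger inhibitor), compound 1 (`O=C(CCc1cccc2c1B(O)OC2)Nc1ccccc1`) gives 350 nM, while compound 2 (`CC(C)(C)c1ccc(NC(=O)CCc2cccc3c2B(O)OC3)cc1`) gives 19000 nM, the higher of the two numbers and therefore the weaker result. Among the measured compounds shown here, the only measured step is large: a 54-fold higher number from compound 1 to compound 2 (1.73 log units; beyond the scatter), with tert-butyl in place of hydrogen on an aromatic carbon. Compound 3 (`COc1ccc(NC(=O)CCc2cccc3c2B(O)OC3)cc1`) keeps the shared core but has methoxy in place of tert-butyl on an aromatic carbon. For the measured compounds named here, no measured compound carries methoxy, so that single step is the only guide. With tert-butyl gone, compound 3 is expected to move back towards compound 1 at 350 nM, probably without reaching it. The expected change is large and downward in this assay: a 13-fold lower number from compound 2 to compound 3 (1.10 log units; beyond the scatter). The estimated value for compound 3 is 1500 nM, within a range of 300 nM to 8000 nM.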

Compound 3, half-maximal inhibitory concentration: 1700 nM
Compound 3: the middle estimate sits 1.1-fold (0.05 log units) below what was measured, and the stated range covers the measured number.
By their numbers in this assay, from the lowest: compound 1; then compound 3; then compound 2.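

In this assay, a group on this aromatic carbon, para to a large group, does not have to cost as much as tert-butyl does: the change to methoxy gives an 11-fold lower number from compound 2 to compound 3 (1.05 log units; beyond the scatter). Methoxy still does not match plain hydrogen, with a 4.9-fold higher number from compound 1 to compound 3 (0.69 log units; beyond the scatter), so both groups give a higher number than hydrogen, methoxy by a modest step and tert-butyl by a large one. No supporting evidence is available to explain this order. Methoxy has fewer heavy atoms than tert-butyl and also adds a hydrogen-bond acceptor, and these compounds cannot show which difference matters, if either does. Going by these compounds, it also remains open whether a fluorine atom, an ethyl group or an amine on this carbon would match compound 1 or fall elsewhere in the order.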